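A few compounds are considered here, and "the series" means these few. Any claim that something is new, unique, unknown or untested is made for them only; others in the source may bear on it.

Measured so far in a physicochemical assay for solubility, at pH 7.4; on this read-out lower numbers stand for lower solubility and higher numbers for higher solubility:
- compound 1 `CCCCCCCc1cn(-c2ccc(CNC(=O)[C@H]3NCC[C@@H]3O)cc2)nn1`: 3.1 ug/mL
- compound 2 `CCCCCCc1nc(-c2ccc(CNC(=O)[C@H]3NCC[C@@H]3O)cc2)no1`: > 50 ug/mL, a limit of the assay and not a number
- compound 3 `CCCCCCCc1noc(-c2ccc(CNC(=O)[C@H]3NCC[C@@H]3O)cc2)n1`: 3 ug/mL

Going by the values given here, of these three compounds, only two have a number. Compound 2 is known only through (the limit of > 50 ug/mL in this assay, at which 1 of the 3 values shown sits). Compound 1 gives 3.1 ug/mL and compound 3 gives 3 ug/mL, two values within the usual scatter of each other. Both of these compounds carry a heptyl chain, and each differs from compound 2 in more than one place, so neither isolates the effect of the chain.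

The next compound to be measured is compound 4 `O=C(NCc1ccc(-c2noc(C3CCCCCC3)n2)cc1)[C@H]1NCC[C@@H]1O`. It keeps the rest of compound 2 and has cycloheptyl in place of hexyl on an aromatic carbon.

Among the compounds with values here, no measured pair shows this change directly, so any expectation for this assay is loose. Within the data shown here, the only guide to direction is compound 3 at 3 ug/mL, which suggests that a larger group on this kind of core may bring a lower reading, though compound 2 differs from it in its core as well. The estimated change is an at least 2.5-fold lower number from compound 2 to compound 4 (0.39 log units; beyond the scatter), a fall that is expected to be moderate. For compound 4 the estimate is 20 ug/mL, with an expected range of 5 ug/mL to 50 ug/mL.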

Compound 4, solubility: > 50 ug/mL
Compound 4 gave a limit, no number; the forecaster's own chance of this, stated with the estimate: 30%; at least 2.5-fold (0.39 log units) between middle value and limit.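

Compound 2 and compound 4 both stand at a limit of this assay and not at a number, so the step from hexyl to cycloheptyl cannot be read: the limit of > 50 ug/mL in this assay, at which 2 of the 4 values shown sit.

As far as these compounds go, whether cycloheptyl and hexyl differ at all on this read-out, and by how much, stays open for these two compounds.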